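This account rests on a few compounds, and the source may have more. Where it says the series, first, only, none or still open, it means among the compounds named here.

In a functional assay on CCRF-CEM cells (Homo sapiens) for cytotoxicity, read by MTT assay, with a stated time of 72 h (a lower number here means a stronger inhibitor of growth, a higher number a weaker inhibitor of growth), compound 2 `CSc1nc(NCCCCc2ccccc2)c2ccccc2n1` gives 47000 nM, the highest of the three numbers in hand, although its gaps to the other two lie within the usual scatter: compound 1 `CSc1nc(NCCCc2ccccc2)c2ccccc2n1` gives 39500 nM, and compound 3 `Nc1nc([SeH])nc2ccccc12` gives 25700 nM. Within the data shown here, the one step measured between close relatives, a 1.2-fold higher number from compound 1 to compound 2 (0.08 log units; within the scatter), did not move the number beyond the scatter. Compound 4 `CSc1nc(NCCCCCO)c2ccccc2n1` differs from compound 2 by hydroxymethyl in place of phenyl on a saturated chain carbon, four bonds along the chain from a nitrogen on an aromatic ring. Among the measured compounds shown here, no measured step exchanges an aromatic ring on the chain for an oxygen-bearing group; the only step on this chain, from compound 1 to compound 2, lengthened it without a shift beyond the scatter, and compound 3, which differs from the others in more than one place, sits close to both. With nothing in hand pointing either way, the step from compound 2 to compound 4 in this assay is expected to stay within the scatter and is estimated at a 1.2-fold higher number from compound 2 to compound 4 (0.07 log units; within the scatter). Compound 4 is therefore estimated to give 55000 nM in this assay, with a range from 20000 nM to 150000 nM.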

Compound 4, concentration for 50% growth inhibition: > 100000 nM
Compound 4 ended at the assay's limit; the forecaster's own chance of this, stated with the estimate: 20%; middle value at least 1.8-fold (0.25 log units) away from the limit.
By their numbers in this assay, from the lowest: compounds 3, 1 and 2 (each within the scatter of the next). At a limit, above all of these: compound 4.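

In this assay, among these compounds, hydroxymethyl in place of phenyl, on a saturated chain carbon four bonds along the chain from a nitrogen on an aromatic ring, gives the first step on this chain that lies beyond the scatter (an at least 2.1-fold higher number from compound 2 to compound 4 (0.32 log units; beyond the scatter)). Read against the shorter chain, as 2-hydroxyethyl in place of phenyl, the change also lies beyond the scatter (an at least 2.5-fold higher number from compound 1 to compound 4 (0.40 log units; beyond the scatter)), whereas lengthening the chain with the phenyl kept stayed within it (a 1.2-fold higher number from compound 1 to compound 2 (0.08 log units; within the scatter)). Compound 4 stands at a limit of the assay and not at a number, so both steps give only a lower bound on the size of the change: the limit of > 100000 nM in this assay, at which 1 of the 4 values shown sits.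

The compounds shown leave open whether the change turns on the phenyl leaving or on the hydroxyl entering, a question a plain alkyl chain in that place would address. On these data alone, how an amine or a carboxylic acid there would read also stays open.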